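This account rests on a few compounds, and the source may have more. Where it says the series, first, only, none or still open, it means among the compounds named here.

Working notes on the series. The shared core is that of compound 1 `O/N=C(/Nc1ccccc1)c1ccc2occc2c1`, which in an assay on tissue (HeLa cells) for inhibition of Indoleamine 2,3-dioxygenase 1 (Homo sapiens), read by spectrophotometry (a lower number here means a stronger inhibitor, a higher number a weaker inhibitor), gives 19000 nM; among the two numbers shown it stands highest, the nearest being compound 3 `O/N=C(/Nc1cccc(Cl)c1)c1ccc2occc2c1` with 1500 nM. Compound 2 `O/N=C(/Nc1ccc(Cl)cc1)c1ccc2occc2c1` reports only a limit of the assay in this assay, > 30000 nM. Two steps from compound 1 exist: an at least 1.5-fold higher number from compound 1 to compound 2 (0.19 log units; that floor lies within the scatter), and a 13-fold lower number from compound 1 to compound 3 (1.10 log units; beyond the scatter). Each adds a single chloro on the aniline-type ring, yet their outcomes point opposite ways, so the ring tolerates change in either direction.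

Compound 4 `CC1CCN(C(=O)c2cccc(N/C(=N/O)c3ccc4occc4c3)c2)CC1` differs from compound 1 by (4-methylpiperidin-1-yl)carbonyl in place of hydrogen on an aromatic carbon. The group entering is far larger than chloro, so neither step transfers directly; both bear on it only as showing the range of outcomes for substitution at this ring. Taking the large step to compound 3 as the nearest guide, but discounting it for the bulk added, a moderate lowering is expected, a 3.8-fold lower number from compound 1 to compound 4 (0.58 log units; beyond the scatter). Compound 4 is therefore estimated at 5000 nM in this assay, with a range from 1000 nM to 25000 nM.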

Compound 4, half-maximal inhibitory concentration: > 30000 nM
Compound 4: only a limit was reported; the forecaster's own chance of this, stated with the estimate: 15%; middle value at least 6.0-fold (0.77 log units) away from the limit.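

In this assay, the gain seen with chloro at this aromatic carbon, meta to a large group, does not carry over to (4-methylpiperidin-1-yl)carbonyl: an at least 20-fold higher number from compound 3 to compound 4 (1.30 log units; beyond the scatter). The other step, an at least 1.5-fold higher number from compound 1 to compound 4 (0.19 log units; that floor lies within the scatter), gives only a floor within the scatter, so it fixes no direction of change. Compound 4 reports only a limit of the assay, the same one as compound 2: the limit of > 30000 nM in this assay, at which 2 of the 4 values shown sit.

Still open, as far as these compounds go, is whether a group such as methyl, methoxy or a primary carboxamide at this place would keep the gain of compound 3, or whether that gain is confined to chloro. Also open, from the compounds shown here alone, is whether the carbonyl or the piperidine ring accounts for the loss in compound 4, and how far that compound lies past its limit.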